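A few compounds are considered here, and "the series" means these few. Any claim that something is new, unique, unknown or untested is made for them only; others in the source may bear on it.

Compound 2 `COc1ccc(NC(=O)c2cn(-c3ccccc3)nc2-c2ccccc2)cc1` gives 1350 nM in a functional assay on HCT-116 cells (Homo sapiens) for cytotoxicity, read by MTT assay, with a stated time of 48 h (a higher number here means a weaker inhibitor, a lower number a stronger inhibitor), the lower of the two numbers measured, while compound 1 `O=C(Nc1ccc(Cl)cc1)c1cn(-c2ccccc2)nc1-c1ccccc1` gives 3520 nM. Among the measured compounds shown here, the single step on record, a 2.6-fold lower number from compound 1 to compound 2 (0.42 log units; beyond the scatter), swaps one group for another on an aromatic carbon and does not test the change at hand. Compound 3 `CCOc1ccc(NC(=O)c2cn(-c3ccccc3)nc2-c2ccccc2)cc1` differs from compound 2 by methyl in place of hydrogen on a saturated chain carbon bound to an oxygen on an aromatic ring, so the methoxy becomes an ethoxy. For the measured compounds named here, no measured step shows what the added methyl does, so no change beyond the scatter is expected in this assay. Compound 3 is therefore estimated at 1300 nM, within 500 nM to 3500 nM, an expected step of a 1.0-fold lower number from compound 2 to compound 3 (0.02 log units; within the scatter).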

Compound 3, half-maximal inhibitory concentration: 620 nM
Beside the measured number, compound 3's estimate is 2.1-fold (0.32 log units) above it; low and high end bracket the measured number.
By their numbers in this assay, from the lowest: compound 3; then compound 2; then compound 1.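

The added methyl matters in this assay and gives a 2.2-fold lower number from compound 2 to compound 3 (0.34 log units; beyond the scatter) on a saturated chain carbon bound to an oxygen on an aromatic ring, so a change at the outer end of this group, and not only a swap on the aromatic carbon, moves the number. Ethoxy in place of chloro gives a 5.7-fold lower number from compound 1 to compound 3 (0.75 log units; beyond the scatter) and is the largest step among these three compounds. Nothing on hand explains why the added methyl has this effect. On these data alone, whether a longer chain, such as propoxy, would lower the number further remains open, and so does what an amine at this place would do.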